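This account rests on a few compounds, and the source may have more. Where it says the series, first, only, none or still open, it means among the compounds named here.

Measured in a functional assay on HCT-116 cells (Homo sapiens) for cytotoxicity, read by scintillation counting and thymidine incorporation, with a stated time of 72 h; on this read-out higher numbers stand for weaker inhibition and lower numbers for stronger inhibition:
compound 1 `CCOc1cc(C(=CC#N)c2ccc(OC)c(F)c2)ccc1OC` gives 130 nM
compound 2 `CC=C(c1cc(OC)cc(OC)c1)c1ccc(OC)c(OC)c1` gives 480 nM
compound 3 `COc1cc(OC)cc(/C(=C/C#N)c2ccc(OC)c(OC)c2)c1` gives 110 nM

Compound 2 gives the highest number of the three; compound 1 and compound 3 both sit lower by amounts beyond the scatter, and those two lie within the scatter of each other. Compound 4 `COc1cc(OC)cc(C(=CC(C)=O)c2ccc(OC)c(OC)c2)c1` is the next entry; relative to compound 2 the change is acetyl in place of methyl on a double-bonded chain carbon bound to a double-bonded chain carbon, an acetyl in place of a methyl on a double-bonded chain carbon. Among the measured compounds shown here, no measured pair isolates this change, so the expectation rests only on the spread of the three numbers: a moderate downward step in this assay is expected, towards where compound 1 and compound 3 lie, but not clearly beyond the scatter. For compound 4 the estimated step is a 2.2-fold lower number from compound 2 to compound 4 (0.34 log units; beyond the scatter). Compound 4 is expected to give 220 nM, with a range from 70 nM to 650 nM.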

Compound 4, half-maximal inhibitory concentration: > 10000 nM
Compound 4: only a limit was reported (the forecaster's own chance of this, stated with the estimate: 5%); middle value at least 45-fold (1.65 log units) away from the limit.
By their numbers in this assay, from the lowest: compounds 3 and 1 (each within the scatter of the next); then compound 2. At a limit, above all of these: compound 4.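

In this assay, the position on a double-bonded chain carbon bound to a double-bonded chain carbon proves sensitive to the group it carries: acetyl in place of methyl gives an at least 20-fold higher number from compound 2 to compound 4 (1.31 log units; beyond the scatter). Among the compounds shown here, this is the first step that isolates a change at this position, and it is large. The result for compound 4 is a limit, not a number: the limit of > 10000 nM in this assay, at which 1 of the 4 values shown sits.

On these data alone, the full size of the step stays open. Whether an amide or a carboxylic acid at this carbon would track acetyl also remains unresolved.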